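The source may report more compounds than this note shows. Statements on the series, on what has been measured and on what is new or still open speak of the compounds shown alone.

Series notes. Compound 1 `O=C1NCCN(c2cccnc2)N1` gives 32000 nM in an assay on RBL-1 cells for inhibition of Polyunsaturated fatty acid 5-lipoxygenase (Rattus norvegicus); on this read-out higher numbers stand for weaker inhibition and lower numbers for stronger inhibition. Compound 2 `O=C1NCCN(c2cccc(Br)n2)N1` gives 3500 nM in this assay, and compound 3 `CC1CN(c2cccc(Br)n2)NC(=O)N1` gives 2400 nM; the change of methyl in place of hydrogen on a saturated ring carbon is a 1.5-fold lower number from compound 2 to compound 3 (0.16 log units; within the scatter). Compound 2 thus holds the second highest of the three numbers, close to compound 3 and far from compound 1. Compound 4 `O=C1NCCN(c2cccc(-c3cccs3)n2)N1` differs from compound 2 by thiophen-2-yl in place of bromo on an aromatic carbon. Within the data shown here, no measured step touches the bromo group; the only step in hand, a 1.5-fold lower number from compound 2 to compound 3 (0.16 log units; within the scatter), lies elsewhere and is within the scatter. Among the measured compounds shown here, compounds 1 and 2 show only that a bromo-bearing core gives a lower number than the unsubstituted one. For the measured compounds named here, with no precedent for thiophen-2-yl, compound 4 is expected to show a step of a 2.3-fold lower number from compound 2 to compound 4 (0.37 log units; beyond the scatter), possibly none beyond the scatter. Compound 4 is estimated at 1500 nM, expected between 300 nM and 8000 nM.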

Compound 4, half-maximal inhibitory concentration: 8200 nM
Compound 4: the middle estimate sits 5.5-fold (0.74 log units) below what was measured, outside the stated range (above it).
By their numbers in this assay, from the lowest: compounds 3 and 2 (each within the scatter of the next); then compound 4; then compound 1.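

At the aromatic carbon next to the ring nitrogen, where earlier steps made no change, thiophen-2-yl in place of bromo gives a 2.3-fold higher number from compound 2 to compound 4 (0.37 log units; beyond the scatter) in this assay. The step lies beyond the scatter but is modest, so this position keeps measurable inhibition with a five-membered aromatic ring in place of a single bromine, and bromo remains the better of the two groups here.

As far as these compounds go, whether an amine, a carboxylic acid or a phenyl ring on this carbon would give a lower number than bromo stays open. Nothing on hand accounts for the direction of this step.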